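The source may hold more compounds than are shown below. What is called first, only, known or untested is meant among the compounds shown, and "the series" means these compounds.

Compound 3 `N#Cc1cccc(Nc2ncnc3cc(NC(=O)/C=C/c4ccccc4)sc23)c1` gives the lowest number of the three measured in a functional assay on MDA-MB-231 cells (Homo sapiens) for antiproliferative activity, read by MTT assay, with a stated time of 48 h (on this read-out higher numbers stand for weaker inhibition and lower numbers for stronger inhibition), with compound 3 at 1040 nM. Compound 1 `C#Cc1cccc(Nc2ncnc3cc(NC(=O)/C=C/c4ccccc4)sc23)c1` stands nearest, with compound 1 at 2340 nM, and compound 2 `O=C(/C=C/c1ccccc1)Nc1cc2c(Nc3ccc(F)c(Cl)c3)ncnc2s1` furthest, with compound 2 at 7600 nM. Going by the values given here, the only step recorded in one place is a 2.3-fold lower number from compound 1 to compound 3 (0.35 log units; beyond the scatter), which is modest and beyond the scatter.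

Compound 4 `O=C(/C=C/c1ccccc1)Nc1cc2ncnc(Nc3ccc(F)c(Cl)c3)c2s1` is reached from compound 3 by 3-chloro-4-fluorophenyl in place of 3-cyanophenyl on a nitrogen on an aromatic ring. Among the compounds with values here, no measured step bears directly on this exchange: the recorded step concerns cyano against ethynyl, not the entering group. Within the data shown here, compound 2 carries the same 3-chloro-4-fluorophenyl group as compound 4 but differs from it in the shared core, so its value shows only that this group, in a different setting, sat far above compound 3. Taken together, a step upward in this assay of moderate size is expected, a 2.4-fold higher number from compound 3 to compound 4 (0.38 log units; beyond the scatter), without confidence in its magnitude. For compound 4 the estimate in this assay is therefore 2500 nM, with a range from 900 nM to 7000 nM expected to hold most repeat measurements.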

Compound 4, half-maximal inhibitory concentration: 2100 nM
For compound 4 the middle estimate is 1.2-fold (0.08 log units) above the measured one, within the range that was stated.
By their numbers in this assay, from the lowest: compound 3; then compounds 4 and 1 (each within the scatter of the next); then compound 2.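

In this assay, the exchange on a nitrogen on an aromatic ring now reaches beyond the earlier cyano against ethynyl comparison: with the shared core kept, 3-chloro-4-fluorophenyl in place of 3-cyanophenyl gives a 2.0-fold higher number from compound 3 to compound 4 (0.31 log units; beyond the scatter), a modest step beyond the scatter. Set against the ethynyl compound, the same entering group gives a 1.1-fold lower number from compound 1 to compound 4 (0.05 log units; within the scatter), so 3-chloro-4-fluorophenyl and 3-ethynylphenyl cannot be told apart at this position in this assay, while 3-cyanophenyl stands clear of both by steps beyond the scatter. No measurement at hand offers a cause for this pattern among the three compounds.

From the compounds shown here alone, the chlorine and the fluorine enter together in one change, so it remains open which of them goes with the step, and how a plain phenyl group carrying neither of them, and no nitrile, would stand on that nitrogen. Also open, going by these compounds, is whether a methoxy group or an amine on the aromatic ring of the entering group would stay with the 3-cyanophenyl compound or with the other two.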